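From 4-bromophenyl to 3-methoxyphenyl: a cytotoxicity estimate

The compounds below may be only part of what the source reports. "The series", "measured", "known", "first", "only" and "open" are said of these compounds alone.

Compound 1 (`Cc1ccc(-n2cc(COc3cccc4cnc(Nc5cccc(Cl)c5)nc34)nn2)c([N+](=O)[O-])c1`): > 25000 nM (a limit)
Compound 2 (`Clc1cccc(Nc2ncc3cccc(OCc4cn(-c5ccc(Br)cc5)nn4)c3n2)c1`): 8000 nM

In a functional assay on NCI-H727 cells (Homo sapiens) for cytotoxicity, read by cell counting, with a stated time of 48 h (on this read-out lower numbers stand for stronger inhibition and higher numbers for weaker inhibition), compound 1 stands at > 25000 nM, which is a limit of the assay. Within the data shown here, compound 2, at 8000 nM, holds the only actual number so far. Compound 3 (`COc1cccc(-n2cc(COc3cccc4cnc(Nc5cccc(Cl)c5)nc34)nn2)c1`) differs from compound 2 on the aromatic nitrogen (3-methoxyphenyl in place of 4-bromophenyl on an aromatic nitrogen). One measured step changes the group at that place (an at least 3.1-fold lower number from compound 1 to compound 2 (0.49 log units; beyond the scatter)), and it starts from a limit. On that evidence, a small step towards weaker inhibition is expected (a 1.5-fold higher number from compound 2 to compound 3 (0.18 log units; within the scatter)), possibly no larger than the scatter. Compound 3 is estimated at 12000 nM (expected range 4000 nM to 25000 nM).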

Compound 3, half-maximal inhibitory concentration: > 25000 nM
Compound 3 was reported as a limit; the forecaster's own chance of this, stated with the estimate: 25%; middle value at least 2.0-fold (0.31 log units) away from the limit.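

In this assay, 3-methoxyphenyl in place of 4-bromophenyl gives an at least 3.1-fold higher number from compound 2 to compound 3 (0.49 log units; beyond the scatter). Of the three groups shown on this aromatic nitrogen, only 4-bromophenyl therefore gives an actual number, and the loss now appears in a step that ends at a limit instead of starting from one. The step between compound 1 and compound 3 cannot be read because both compounds stand at a limit: the limit of > 25000 nM in this assay, at which 2 of the 3 values shown sit.

From the compounds shown here alone, how a 4-methoxyphenyl or a 4-chlorophenyl would read on this nitrogen remains open. The compounds shown therefore do not separate the kind of group from its place on the phenyl ring.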